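The compounds below may be only part of what the source reports. "The series", "measured", "known", "first", "only" and "open" are said of these compounds alone.

In a functional assay on P388 cells (Mus musculus) for cytotoxicity (on this read-out higher numbers stand for weaker inhibition and lower numbers for stronger inhibition), compound 1 (`Brc1ccc2c(-c3c[nH]c(-c4c[nH]c5ccccc45)n3)c[nH]c2c1`) gives 4500 nM, and compound 2 (`Brc1ccc2cc(-c3c[nH]c(-c4c[nH]c5cc(Br)ccc45)n3)[nH]c2c1`) gives 4500 nM. Compound 2 therefore stands level with compound 1, and the two values show no difference beyond the usual scatter. The next compound to be tested is compound 3 (`Brc1ccc2c(-c3nc(-c4cc5ccccc5[nH]4)c[nH]3)c[nH]c2c1`). Going from compound 2 to compound 3, the structural change is hydrogen in place of bromo on an aromatic carbon, with hydrogen in place of bromo on an aromatic carbon. Going by the values given here, no measured step between compounds isolates this change, so the data offer no direct guide to its size or direction. The only basis is that the two measured compounds sit together, so no shift beyond the scatter is expected in this assay. The estimated step is a 1.1-fold higher number from compound 2 to compound 3 (0.05 log units; within the scatter). For compound 3 the expected value is 5000 nM, within an estimated range of 2000 nM to 12000 nM.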

Compound 3, half-maximal inhibitory concentration: 4500 nM
The estimate for compound 3 lay 1.1-fold (0.05 log units) above the measured number, within the range that was stated.
By their numbers in this assay, from the lowest: compounds 1, 2 and 3 (each within the scatter of the next).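

In this assay, going by these compounds alone, the first step that isolates this change, hydrogen in place of bromo on an aromatic carbon, reads no change at the digits printed from compound 2 to compound 3 (within the scatter), so on this six-membered aromatic ring of carbon only, part of a fused system of two rings, the swap leaves the number within the scatter. At this position, then, bromo and hydrogen cannot be told apart by this read-out, something the earlier pair could not show because no step had been listed for it. Nothing among the data offers an explanation for this result. The compounds shown cover only bromo and hydrogen here, so it remains open whether a larger change, such as an amine, a carboxylic acid or a longer alkyl chain at this position, would move the number beyond the scatter.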